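A few compounds are considered here, and "the series" means these few. Any claim that something is new, unique, unknown or untested is made for them only; others in the source may bear on it.

Measured so far:
compound 1, `O=C1NC(=O)C(Cc2ccc(Oc3ccc(C(F)(F)F)cc3Cl)cc2)S1`, in a functional assay for agonist activity at Free fatty acid receptor 1 (Homo sapiens), read by FLIPR, in the presence of a further agent that is not named here (on this read-out higher numbers stand for an effect only at larger amounts of compound and lower numbers for an effect already at smaller amounts), gives 78 nM
compound 2, `Cc1ccnc(Oc2ccc(CC3SC(=O)NC3=O)cc2)c1`, in this assay gives 4280 nM
compound 3, `O=C1NC(=O)C(Cc2ccc(Oc3cc(C(F)(F)F)ccn3)cc2)S1`, in this assay gives 237 nM

Compound 2 stands at the highest number of the three in this assay; its nearest neighbour is compound 3, and compound 1 lies furthest from it. The unmeasured compound 4, `O=C1NC(=O)C(Cc2ccc(Oc3ccc(Cl)cc3)cc2)S1`, differs from compound 2 in one place: 4-chlorophenyl in place of 4-methylpyridin-2-yl on an oxygen on an aromatic ring.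

Going by the values given here, only one measured step touches this region of the molecule, the exchange of methyl for trifluoromethyl on the aromatic carbon, which gave an 18-fold lower number from compound 2 to compound 3 (1.26 log units; beyond the scatter). Among the compounds with values here, no measured pair shows the exchange of the ring itself, and compound 1 and compound 3, which differ in more than one place, show only that the carbon ring bearing chlorine and trifluoromethyl sits at a lower number than the pyridine ring bearing trifluoromethyl. Compound 4 keeps the chlorine but carries no trifluoromethyl, so for it a clear drop from compound 2 is expected, though smaller than that seen for compound 3: an estimated 8.6-fold lower number from compound 2 to compound 4 (0.93 log units; beyond the scatter), giving 500 nM with a range from 150 nM to 1600 nM.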

Compound 4, half-maximal effective concentration: 240 nM
Compound 4: the middle estimate sits 2.1-fold (0.32 log units) above what was measured; the measured number falls inside the stated range.
By their numbers in this assay, from the lowest: compound 1; then compounds 3 and 4 (each within the scatter of the next); then compound 2.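

Going by these compounds alone, the exchange of the whole ring on the oxygen, which the earlier compounds did not cover, gives an 18-fold lower number from compound 2 to compound 4 (1.25 log units; beyond the scatter) in this assay and shows that this position does not depend on the pyridine ring, since 4-chlorophenyl, a ring of carbon only, also takes the number well down. Within the data shown here, it also shows that trifluoromethyl is not the only change here that gives a large step from compound 2, as compound 4 carries chlorine and no trifluoromethyl. Nothing available explains the size of this step.

Because the ring atom and the ring substituent change together, the compounds shown do not separate their shares in the step. On these data alone, a 4-chloropyridin-2-yl or 4-methylphenyl group on the same oxygen would tell them apart, and a nitrile or an amine in place of the chlorine remains open.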